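The source may hold more compounds than are shown below. What is called first, only, known or untested is meant among the compounds shown, and "the series" means these compounds.

Compound 1 `CCC(C)(O)CC(=O)O[C@H](CC=C(C)C)C1=CC(=O)c2c(O)ccc(O)c2C1=O` carries a (2-hydroxy-2-methylbutyl)carbonyl group on an oxygen on a saturated carbon. In a functional assay on DU-145 cells (Homo sapiens) for cytotoxicity, read by MTT assay (on this read-out lower numbers stand for stronger inhibition and higher numbers for weaker inhibition), compound 1 gives 16000 nM, the lowest of the two numbers here. Compound 3 `CC[C@](C)(O)CC(=O)O[C@H](CC=C(C)C)C1=CC(=O)c2c(O)ccc(O)c2C1=O` gives 20500 nM, and the step of a 1.3-fold higher number from compound 1 to compound 3 (0.11 log units; within the scatter) lies within the scatter, which fits (the fact that one of compounds 1 and 3 is drawn with a defined configuration and the other without, at the place where they differ). Compound 2 `CCCC(O)CC(=O)O[C@H](CC=C(C)C)C1=CC(=O)c2c(O)ccc(O)c2C1=O` reports only a limit, > 100000 nM. The step of an at least 6.2-fold higher number from compound 1 to compound 2 (0.79 log units; beyond the scatter) lies beyond the scatter. Compound 4 `COCCO[C@H](CC=C(C)C)C1=CC(=O)c2c(O)ccc(O)c2C1=O` differs from compound 1 by 2-methoxyethyl in place of (2-hydroxy-2-methylbutyl)carbonyl on an oxygen on a saturated carbon. Among the measured compounds shown here, no measured step shows this change directly; the nearest guide is that altering the acyl part, from compound 1 to compound 2, raised the number. Compound 4 is therefore expected to give a weaker result, a step of a 2.8-fold higher number from compound 1 to compound 4 (0.45 log units; beyond the scatter). Compound 4 is estimated at 45000 nM, between 12000 nM and 150000 nM.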

Compound 4, half-maximal inhibitory concentration: 43200 nM
The estimate for compound 4 lay 1.0-fold (0.02 log units) above the measured number; the measured number falls inside the stated range.
By their numbers in this assay, from the lowest: compounds 1 and 3 (each within the scatter of the next); then compound 4. At a limit, above all of these: compound 2.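

The acyl group on this oxygen is not essential: the smaller 2-methoxyethyl, with no hydrogen-bond donor, still gives a measurable number, though at a modest cost, with a 2.7-fold higher number from compound 1 to compound 4 (0.43 log units; beyond the scatter) and a 2.1-fold higher number from compound 3 to compound 4 (0.32 log units; beyond the scatter). Compound 2 is known only as a limit, so an at least 2.3-fold lower number from compound 2 to compound 4 (0.36 log units; beyond the scatter) is a bound, yet it places the ether on the stronger side of that unbranched ester: the limit of > 100000 nM in this assay, at which 1 of the 4 values shown sits.

From the compounds shown here alone, the hydroxyl and the carbonyl leave together here, so their separate contributions stay open. Going by these compounds, whether a longer ether chain or an amine at this oxygen would do better also remains unknown.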